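Piperazinyl in Place of a Thiazolinylthio Group

A few compounds are considered here, and "the series" means these few. Any claim that something is new, unique, unknown or untested is made for them only; others in the source may bear on it.

Of the compounds shown here, three sharing one core have been measured in a functional assay on HT-29 cells (Homo sapiens) for cytotoxicity, read by MTT assay, with a stated time of 24 h, tested at 6.4 ug/mL; on this read-out lower numbers stand for a weaker effect and higher numbers for a stronger effect at the one concentration tested. Compound 1 `Cn1c(-c2ccc(NC(=O)CCl)cc2)nc(-c2ccccc2)c1-c1ccccc1` gives 15.1%, compound 2 `Cn1c(-c2ccc(NC(=O)CSc3nc4ccccc4o3)cc2)nc(-c2ccccc2)c1-c1ccccc1` gives 44.9%, and compound 3 `Cn1c(-c2ccc(NC(=O)CSC3=NCCS3)cc2)nc(-c2ccccc2)c1-c1ccccc1` gives 31%. Compound 3 stands second highest of the three numbers: the step of a number 13.9 percentage points lower from compound 2 to compound 3 (beyond the scatter) separates it from compound 2, its nearest neighbour, and the step of a number 15.9 percentage points higher from compound 1 to compound 3 (beyond the scatter) from compound 1, the furthest.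

Compound 4 `CCN1CCN(CC(=O)Nc2ccc(-c3nc(-c4ccccc4)c(-c4ccccc4)n3C)cc2)CC1` differs from compound 3 in one place: a group of 8 heavy atoms (6 carbon, 2 nitrogen; one six-membered non-aromatic ring with 2 hetero atoms) in place of a group of 6 heavy atoms (3 carbon, 1 nitrogen, 2 sulfur; one five-membered non-aromatic ring with 2 hetero atoms), on a saturated chain carbon bound to a carbonyl carbon. For the measured compounds named here, no measured step puts a 4-ethylpiperazin-1-yl on that saturated chain carbon bound to a carbonyl carbon. Going by the values given here, the steps that bear on the position are a number 29.8 percentage points higher from compound 1 to compound 2 (beyond the scatter) and a number 15.9 percentage points higher from compound 1 to compound 3 (beyond the scatter), each raising the read-out when chlorine gives way to a larger group, while a number 13.9 percentage points lower from compound 2 to compound 3 (beyond the scatter) shows that the choice of group also moves it. Compound 4 is therefore expected to fall within the span of the three, as a step of a number 5 percentage points lower from compound 3 to compound 4 (within the scatter) that may not exceed the scatter. Compound 4 is estimated at 26%, with a range from 10% to 45%.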

Compound 4, a percentage reported as activity, at one concentration (the size of the read-out at that concentration, not a potency): 17.2%
Estimate against measurement, compound 4: 8.8 percentage points above, and the stated range covers the measured number.
By their numbers in this assay, from the lowest: compounds 1 and 4 (each within the scatter of the next); then compound 3; then compound 2.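

In this assay, for the compounds shown here, the earlier compounds left the impression that any larger group in place of chloro on a saturated chain carbon bound to a carbonyl carbon raises the read-out, but compound 4 goes against this, with the step of a number 2.1 percentage points higher from compound 1 to compound 4 (within the scatter). The two groups held on a sulfur stand apart from 4-ethylpiperazin-1-yl, as the steps of a number 13.8 percentage points lower from compound 3 to compound 4 (beyond the scatter) and a number 27.7 percentage points lower from compound 2 to compound 4 (beyond the scatter) show, so across these four compounds the read-out depends on the identity of the group and does not follow its heavy-atom count alone. Nothing measured here explains the difference between these groups.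

On these data alone, it remains open whether the result belongs to the piperazine ring itself, the ethyl on it, or the missing sulfur. A morpholine ring, an unsubstituted piperazine or a diethylamino group on the same carbon would help to separate these possibilities.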